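The compounds below may be only part of what the source reports. "The series", "measured", "known", "first", "only" and "open" are said of these compounds alone.

Measured so far in an in vivo ADME assay on the whole organism (Rattus norvegicus) for pharmacokinetics; a lower number here means that a smaller share of the oral dose reaches the circulation, a higher number that a larger share of the oral dose reaches the circulation:

compound 1, `O=C(O)[C@@H](CC1CCC1)N1C[C@H](CN2CCC(c3cnc4ccc(Cl)cn34)CC2)[C@@H](c2cccc(F)c2)C1`: 26%
compound 2, `O=C(O)[C@@H](CC1CCC1)N1C[C@H](CN2CCC(c3cnc4ccc(F)cn34)CC2)[C@@H](c2cccc(F)c2)C1`: 38%

For the measured compounds named here, compound 2 stands highest of the two numbers in this assay; its nearest neighbour is compound 1, and the step of a number 12 percentage points higher from compound 1 to compound 2 (beyond the scatter) is the only measured step in the set. Compound 3, `CCc1ccn2c(C3CCN(C[C@H]4CN([C@H](CC5CCC5)C(=O)O)C[C@@H]4c4cccc(F)c4)CC3)cnc2c1`, is not yet measured. It differs from compound 2 as follows: a group of 11 heavy atoms (9 carbon, 2 nitrogen; one five-membered aromatic ring with 2 hetero atoms, one six-membered aromatic ring with 1 hetero atom) in place of a group of 10 heavy atoms (7 carbon, 2 nitrogen, 1 fluorine; one five-membered aromatic ring with 2 hetero atoms, one six-membered aromatic ring with 1 hetero atom), on a saturated ring carbon.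

Going by the values given here, the one measured step bears only loosely on this change. It exchanged one halogen for another on an aromatic carbon and lifted the oral bioavailability modestly, whereas here the whole group that carries the fluorine leaves the saturated ring carbon and a group with no halogen enters in its place. Among the compounds with values here, no measured pair shows what such an exchange does in this assay, so no step beyond the scatter is expected in either direction, and the anchor is compound 2, which in this assay gives 38%. Compound 3 is therefore estimated at 32%, within a range from 15% to 50%. The step of a number 6 percentage points lower from compound 2 to compound 3 (within the scatter) is the change this estimate expects, and it is expected to stay within the scatter.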

Compound 3, oral bioavailability: 11%
Compound 3: the middle estimate sits 21 percentage points above what was measured; the whole stated range lies above it.
By their numbers in this assay, from the lowest: compound 3; then compound 1; then compound 2.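

Working notes on the group on the saturated ring carbon: in this assay, replacing the fluorine-bearing group of 10 heavy atoms with the halogen-free group of 11 heavy atoms gives a number 27 percentage points lower from compound 2 to compound 3 (beyond the scatter), and replacing the chlorine-bearing group of 10 heavy atoms with the same group gives a number 15 percentage points lower from compound 1 to compound 3 (beyond the scatter). For the compounds shown here, the earlier pair showed only that the choice of halogen can shift this read-out; these steps show that a halogen-free group at this place can take the number below both halogen-bearing compounds, with no compound among the three going against that order. No measurement shown here gives a reason for this drop.

Two compounds sharing the same two aromatic ring types but differing in their substituent cannot separate the loss of the halogen from the other differences between the groups, since the halogen-free group also differs in its carbon count. Open questions are how a group with the same two aromatic rings carrying a methyl, a methoxy or a nitrile would stand in this assay, and whether the order seen here would hold for any of them.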